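Swapping fluoro for bromo on the aryl triazole of compound 3

The source may report more compounds than this note shows. Statements on the series, on what has been measured and on what is new or still open speak of the compounds shown alone.

Measured so far:
Compound 1, `CC1(C)[C@H]2CC[C@]1(C)N(Cc1cn(-c3ccccc3Br)nn1)C(=O)C2`: 140 nM
Compound 2, `CC1(C)[C@H]2CC[C@]1(C)N(Cc1cn(-c3ccccc3F)nn1)C(=O)C2`: 300 nM
Compound 3, `CC1(C)[C@H]2CC[C@]1(C)N(Cc1cn(-c3ccc(F)cc3)nn1)C(=O)C2`: 200 nM

All three share one core and differ only in the halogen on the phenyl ring attached to the triazole. In a functional assay on OVCAR-3 cells (Homo sapiens) for inhibition, read by MTT assay, with a stated time of 24 h (on this read-out higher numbers stand for weaker inhibition and lower numbers for stronger inhibition), compound 3 gives 200 nM, a number that sits close to those of compound 1 and compound 2, within the usual scatter of each, so none of the three can be told apart with confidence except compound 1 from compound 2.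

Compound 4, `CC1(C)[C@H]2CC[C@]1(C)N(Cc1cn(-c3ccc(Br)cc3)nn1)C(=O)C2`, has not yet been measured. It differs from compound 3 by bromo in place of fluoro on an aromatic carbon. Among the compounds with values here, the one measured step that bears on this swap is a 2.1-fold higher number from compound 1 to compound 2 (0.33 log units; beyond the scatter), where the exchange ran the other way, fluoro replacing bromo, and gave a modestly weaker inhibitor. Reversing that direction here, a modestly lower number is expected in this assay, about a 1.7-fold lower number from compound 3 to compound 4 (0.22 log units; within the scatter). Compound 4 is therefore estimated at 120 nM, with a likely range from 60 nM to 280 nM.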

Compound 4, half-maximal inhibitory concentration: 140 nM
Beside the measured number, compound 4's estimate is 1.2-fold (0.07 log units) below it; measured number inside the range.
By their numbers in this assay, from the lowest: compounds 1, 4, 3 and 2 (each within the scatter of the next, the first and the last beyond it).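

The move from 4-fluorophenyl to 4-bromophenyl gives a 1.4-fold lower number from compound 3 to compound 4 (0.15 log units; within the scatter), so at this place on the ring the two halogens cannot be told apart. Moving the bromo group, with 4-bromophenyl in place of 2-bromophenyl, gives no change at the digits printed from compound 1 to compound 4 (within the scatter), while 4-bromophenyl in place of 2-fluorophenyl gives a 2.1-fold lower number from compound 2 to compound 4 (0.33 log units; beyond the scatter), the only one of these three steps large enough to read as real. The exchange of fluoro for bromo can now be read on two pairs of compounds, and the two readings agree within the noise: the same change on two cores in this assay, a 2.1-fold higher number (0.33 log units; beyond the scatter) from compound 1 to compound 2 and a 1.4-fold higher number (0.15 log units; within the scatter) from compound 4 to compound 3, 1.5-fold (0.18 log units) apart, within the scatter of two such steps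

As far as these compounds go, every compound here carries a single halogen on the phenyl ring, so what an amine, a methoxy group or a carboxylic acid would do at this place remains open. So does how a plain phenyl ring with no halogen would compare.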